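The source may hold more compounds than are shown below. What is called first, only, known or untested is meant among the compounds shown, and "the series" means these compounds.

Among the compounds with values here, compound 2, `CCCCNc1nc(N)c2nc(O)n(Cc3ccccc3)c2n1`, is the compound with the lowest number among the two measured so far in a functional assay on the whole organism for activation, with Mus musculus as the target; on this read-out lower numbers stand for an effect already at smaller amounts and higher numbers for an effect only at larger amounts of compound. In this assay compound 2 gives 0.1 mg/kg. Within the data shown here, the only other measured compound is compound 1, `Nc1nc(O)nc2c1nc(O)n2Cc1ccccc1`, which in this assay gives 1 mg/kg; the step of a 10-fold lower number from compound 1 to compound 2 (1.00 log units; beyond the scatter) separates the two, and it arises from butylamino in place of hydroxy on an aromatic carbon.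

The unmeasured compound 3 is `CCOc1nc(N)c2nc(O)n(Cc3ccccc3)c2n1`. It differs from compound 2 by ethoxy in place of butylamino on an aromatic carbon. Among the measured compounds shown here, the one measured step that bears on this position is a 10-fold lower number from compound 1 to compound 2 (1.00 log units; beyond the scatter): it shows that the group on this aromatic carbon shifts the number well beyond the scatter, since hydroxy and butylamino stand far apart. Ethoxy is neither of these two groups, so the account rests on a single step and no direct comparison of ethoxy with butylamino exists. Compound 3 is therefore expected to give a somewhat higher number than compound 2, by an estimated 3.0-fold higher number from compound 2 to compound 3 (0.48 log units; beyond the scatter), while remaining below the number of compound 1. The estimate for compound 3 in this assay is 0.3 mg/kg, with a range from 0.1 mg/kg to 1 mg/kg.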

Compound 3, minimum effective dose: 0.3 mg/kg
Compound 3: the middle estimate sits on the measured number at the digits printed; low and high end bracket the measured number.
By their numbers in this assay, from the lowest: compound 2; then compound 3; then compound 1.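

At the aromatic carbon between two ring nitrogen atoms, a third group now gives a reading in this assay, and the two new steps place ethoxy between hydroxy and butylamino. The step of a 3.3-fold lower number from compound 1 to compound 3 (0.52 log units; beyond the scatter) shows that ethyl in place of hydrogen on the oxygen is enough on its own to move the number beyond the scatter, so the shift seen earlier does not require a nitrogen-linked chain at this position. The step of a 3.0-fold higher number from compound 2 to compound 3 (0.48 log units; beyond the scatter) adds that the choice among substituted groups still matters, since ethoxy and butylamino are also separated beyond the scatter, although ethoxy differs from butylamino in both its linking atom and its chain length. The data offer no measured explanation for any of these differences.

On these data alone, it remains open whether the linking oxygen or the shorter chain accounts for the step from butylamino to ethoxy, a question that butoxy or ethylamino at the same carbon would address. Also open, as far as these compounds go, is how far the number would move with a methoxy group, a longer chain or a cyclic amine at this position.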